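Formyl in place of ethoxycarbonyl on the triazole aryl ring

A few compounds are considered here, and "the series" means these few. Any claim that something is new, unique, unknown or untested is made for them only; others in the source may bear on it.

The series shares a core carrying a methoxy group and an enone chain, linked through a benzylic ether to a triazole bearing an aryl group. Compound 1 `COc1cc(/C=C/C(C)=O)ccc1OCc1cn(-c2c(F)cccc2F)nn1` gives 2030 nM in a functional assay on MCF7 cells (Homo sapiens) for antiproliferative activity, read by MTT assay, with a stated time of 48 h; on this read-out higher numbers stand for weaker inhibition and lower numbers for stronger inhibition. Compound 2 `COc1ccc(-n2cc(COc3ccc(/C=C/C(C)=O)cc3OC)nn2)cc1` gives 33700 nM in this assay, and a 17-fold higher number from compound 1 to compound 2 (1.22 log units; beyond the scatter). Compound 3 `CCOC(=O)c1ccc(-n2cc(COc3ccc(/C=C/C(C)=O)cc3OC)nn2)cc1` reaches only a limit of this assay, > 100000 nM, so its position is known only as a limit and not as a number. The step of an at least 2.9-fold higher number from compound 2 to compound 3 (0.47 log units; beyond the scatter) shows that the ethoxycarbonyl compound sits among the weakest of the three, although the limit of > 100000 nM in this assay, at which 1 of the 3 values shown sits, leaves its exact standing open. Compound 4 `COc1cc(/C=C/C(C)=O)ccc1OCc1cn(-c2ccc(C=O)cc2)nn1` differs from compound 3 by hydrogen in place of ethoxy on a carbonyl carbon. Within the data shown here, no measured step touches the carbonyl carbon itself, so the two steps already seen bear on it only indirectly, and neither points to a recovery of inhibition. The expected step of an at least 1.6-fold lower number from compound 3 to compound 4 (0.22 log units; that floor lies within the scatter) is therefore small, and compound 4 is estimated at 60000 nM with a range of 12000 nM to 300000 nM.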

Compound 4, half-maximal inhibitory concentration: 86400 nM
Beside the measured number, compound 4's estimate is 1.4-fold (0.16 log units) below it; measured number inside the range.
By their numbers in this assay, from the lowest: compound 1; then compound 2; then compound 4. At a limit, above all of these: compound 3.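

Going by these compounds, the change from ethoxycarbonyl to formyl gives an at least 1.1-fold lower number from compound 3 to compound 4 (0.06 log units; that floor lies within the scatter), which establishes no gain in inhibition, and the true size of this step stays open because compound 3 is held only by a limit: the limit of > 100000 nM in this assay, at which 1 of the 4 values shown sits. Compound 4 nevertheless gives a measured number for a carbonyl-bearing group on the aryl ring, and formyl stays behind methoxy at this place, with a 2.6-fold higher number from compound 2 to compound 4 (0.41 log units; beyond the scatter). The gap to the 2,6-difluorophenyl compound is far larger, at a 43-fold higher number from compound 1 to compound 4 (1.63 log units; beyond the scatter).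

On these data alone, whether a carboxylic acid or a hydroxymethyl group in place of formyl would bring the number back toward that of compound 2 stays open. So does the effect of a single fluorine on the phenyl ring in place of the 4-formyl group.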